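The compounds below may be only part of what the source reports. "The series", "measured", "known", "first", "only" and "open" are said of these compounds alone.

Measured so far in a functional assay for agonist activity at G protein-coupled receptor 88 (Homo sapiens), read by HTRF and cAMP accumulation; a lower number here means that less compound is needed, a higher number that more compound is needed for the effect:
- compound 1, `CC[C@H](C)[C@H](N)CN(C(=O)[C@@H]1C[C@H]1c1cccc(F)c1)c1ccc(-c2ccccc2)cc1`: 560 nM
- compound 2, `CC[C@H](C)[C@H](N)CN(C(=O)[C@@H]1C[C@H]1c1ccncc1)c1ccc(-c2ccccc2)cc1`: 1500 nM
- compound 3, `CC[C@H](C)[C@H](N)CN(C(=O)[C@@H]1C[C@H]1c1cncnc1)c1ccc(-c2ccccc2)cc1`: 19000 nM

Compound 3 gives the highest number of the three in this assay; compound 2 is the nearest, and compound 1 the furthest from it. The two steps that lead to compound 3 are a 34-fold higher number from compound 1 to compound 3 (1.53 log units; beyond the scatter) and a 13-fold higher number from compound 2 to compound 3 (1.10 log units; beyond the scatter), both large, while the step of a 2.7-fold higher number from compound 1 to compound 2 (0.43 log units; beyond the scatter) is modest.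

Compound 4, `CC[C@H](C)[C@H](N)CN(C(=O)[C@@H]1C[C@H]1c1csc(C)n1)c1ccc(-c2ccccc2)cc1`, is not yet measured. It differs from compound 3 in one place: 2-methyl-1,3-thiazol-4-yl in place of pyrimidin-5-yl on a saturated ring carbon. Among the compounds with values here, no measured step covers this exact exchange. The measured steps all concern the aromatic group on the saturated ring carbon, and each change of that group moved this assay beyond the scatter, so a step beyond the scatter is expected here too. Given that compound 3 stands at the top of the range, with 19000 nM, the expected direction for compound 4 is toward a lower number, roughly back into the region of compound 2 or compound 1, though it is an estimate resting only on three compounds.

Compound 4 is therefore expected to give about 2500 nM in this assay, within 600 nM to 10000 nM, an estimated step of a 7.6-fold lower number from compound 3 to compound 4 (0.88 log units; beyond the scatter).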

Compound 4, half-maximal effective concentration: 1500 nM
Compound 4: the middle estimate sits 1.7-fold (0.22 log units) above what was measured; measured number inside the range.
By their numbers in this assay, from the lowest: compound 1; then compounds 2 and 4 (each within the scatter of the next); then compound 3.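

In this assay, 2-methyl-1,3-thiazol-4-yl in place of pyrimidin-5-yl gives a 13-fold lower number from compound 3 to compound 4 (1.10 log units; beyond the scatter), so a five-membered aromatic ring is workable at this saturated ring carbon, and the large step comes with no change in the counts of heavy atoms or hydrogen-bond acceptors. Against the six-membered aromatic groups, the same group shows no change at the digits printed from compound 2 to compound 4 (within the scatter), while a 2.7-fold higher number from compound 1 to compound 4 (0.43 log units; beyond the scatter) leaves compound 1 with the lowest number of the series. No measurement is available that would explain these differences between aromatic groups.

Still open, as far as these compounds go, is how a saturated amine such as piperidin-4-yl, or a carboxylic acid, would read at this ring carbon. Also open, from the compounds shown here alone, is what the methyl of the 2-methyl-1,3-thiazol-4-yl group contributes to the number of compound 4.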